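Notes on a halogen-for-methyl exchange in the series

The source may hold more compounds than are shown below. What is called first, only, known or untested is meant among the compounds shown, and "the series" means these compounds.

Two compounds of the series carry numbers in an assay on isolated protein for inhibition of kynurenine--oxoglutarate transaminase 1 (Homo sapiens), read by HPLC, with a stated time of 20 min; on this read-out higher numbers stand for weaker inhibition and lower numbers for stronger inhibition. Compound 1 `CCOC(=O)/C(CCCC(=O)O)=N\Nc1ccc(Cl)cc1`, the chloro analogue, gives 20000 nM in this assay. Compound 2 `CCOC(=O)/C(CCCC(=O)O)=N\Nc1ccc(C)cc1`, the methyl analogue, gives 33000 nM in this assay. Compound 2 stands at the higher of the two numbers, but the step of a 1.7-fold higher number from compound 1 to compound 2 (0.22 log units; within the scatter) lies within the scatter, so no order between the two is read from it.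

Compound 3 `CCOC(=O)/C(CCCC(=O)O)=N\Nc1ccc(I)cc1` is the next member of the series: iodo in place of methyl on an aromatic carbon, on an aromatic carbon of a six-membered aromatic ring of carbon only, para to a large group. Among the measured compounds shown here, the only measured step bearing on this change is a 1.7-fold higher number from compound 1 to compound 2 (0.22 log units; within the scatter), which exchanged a halogen for methyl at the same place and moved the number by less than the scatter. Putting a halogen back in place of methyl is therefore expected to give a step of comparable size in this assay, towards a lower number if any, and nothing beyond the scatter is expected. The expected step is a 1.7-fold lower number from compound 2 to compound 3 (0.22 log units; within the scatter). Compound 3 is expected to give 20000 nM in this assay, with a range from 8000 nM to 50000 nM.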

Compound 3, half-maximal inhibitory concentration: 34000 nM
The estimate for compound 3 lay 1.7-fold (0.23 log units) below the measured number, and the stated range covers the measured number.
By their numbers in this assay, from the lowest: compounds 1, 2 and 3 (each within the scatter of the next).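

In this assay, iodo in place of methyl on an aromatic carbon, para to a large group, gives a 1.0-fold higher number from compound 2 to compound 3 (0.01 log units; within the scatter) and iodo in place of chloro at the same place gives a 1.7-fold higher number from compound 1 to compound 3 (0.23 log units; within the scatter) in the same read-out. With a third group now at this position, every pair among compound 1, compound 2 and compound 3 lies within the scatter, so the numbers set neither the two halogens apart from methyl nor the iodo analogue apart from the chloro analogue, and no order among the three can be read. No measurement is at hand that would account for this flat result at the position.

As far as these compounds go, whether a group of another kind at this place, such as an amine, a carboxylic acid or a methoxy group, would move the number beyond the scatter remains open. Also open, from the compounds shown here alone, is whether any change elsewhere on the shared core, such as a longer chain or an amide in place of the ethyl ester, would give a step larger than those seen here.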